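The compounds below may be only part of what the source reports. "The series", "measured", "known", "first", "only" and "open" are said of these compounds alone.

The series rests on a shared core, that of compound 1 `Cc1cnc(C(=O)Nc2cc(OCCC3CCNCC3)cc3cccnc23)cn1`, in which an amide-linked heteroaryl group and an ether-linked basic side chain are joined to the same bicyclic scaffold. Compound 2 `NCCOc1cc(NC(=O)c2ncccn2)c2ncccc2c1` carries the shortest side chain of the set, and compound 3 `CC(C)(C)OC(=O)N1CCC(CCOc2cc(NC(=O)c3ncccn3)c3ncccc3c2)CC1` carries the longest, with its ring amine capped by a tert-butoxycarbonyl group.

In a functional assay on PANC-1 cells (Homo sapiens) for inhibition, read by MTT assay, with a stated time of 72 h (a higher number here means a weaker inhibitor, a lower number a stronger inhibitor), compound 1 gives > 10000 nM, which is a limit of the assay rather than a number. Compound 2 likewise reaches only the limit, at > 10000 nM. Compound 3 stands at the same limit, giving > 10000 nM in this assay. Nothing in this set therefore separates one compound from another; all that is known is the limit of > 10000 nM in this assay, at which 3 of the 3 values shown sit.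

Compound 4 `O=C(Nc1cc(OCCC2CCNCC2)cc2cccnc12)c1ncccn1` differs from compound 3 by hydrogen in place of tert-butoxycarbonyl on an amine nitrogen in a ring. Among the measured compounds shown here, no measured step guides this change. Compound 1, which also bears a free ring amine, sits at the limit, so no gain beyond the scatter is expected here, and compound 4 is estimated to remain at or near the limit, with a step that the limit leaves unreadable from compound 3 to compound 4. Compound 4 is thus expected to give about 15000 nM in this assay, within a range from 5000 nM to 50000 nM.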

Compound 4, half-maximal inhibitory concentration: > 10000 nM
Compound 4: only a limit was reported; the forecaster's own chance of this, stated with the estimate: 80%; the middle value lies beyond the limit too.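

In this assay compound 4 gives > 10000 nM, which is a limit of the assay. Among the compounds shown here, its steps from compound 1, compound 2 and compound 3 therefore cannot be read, and no new step follows from this result. The compounds shown leave open which change on the shared core, if any, would give a readable value in this assay, with the set standing at: the limit of > 10000 nM in this assay, at which 4 of the 4 values shown sit.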